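Boron-containing amides: cytotoxicity in human fibroblasts

This account rests on a few compounds, and the source may have more. Where it says the series, first, only, none or still open, it means among the compounds named here.

Compounds measured:
compound 1 `O=C(CCc1cccc2c1B(O)OC2)Nc1nccs1`: > 100000 nM
compound 2 `O=C(CCc1cccc2c1B(O)OC2)Nc1cccc(I)c1`: 71000 nM

In an ADME assay on WI-38 cells (Homo sapiens) for cytotoxicity, read by MTT assay, with a stated time of 72 h (on this read-out lower numbers stand for stronger inhibition and higher numbers for weaker inhibition), compound 1 reaches only a limit, > 100000 nM. In this assay compound 2 gives 71000 nM, the only number shown. Within the data shown here, the one measured step, an at least 1.4-fold lower number from compound 1 to compound 2 (0.14 log units; that floor lies within the scatter), rests on the limit of > 100000 nM in this assay, at which 1 of the 2 values shown sits, and concerns the aryl on the amide nitrogen. Compound 3 `N#Cc1cccc(-c2cccc(NC(=O)CCc3cccc4c3B(O)OC4)c2)c1` differs from compound 2 elsewhere: 3-cyanophenyl in place of iodo on an aromatic carbon. Among the measured compounds shown here, no measured step touches that position, so little change beyond the scatter is expected. Compound 3 is estimated at 50000 nM, between 15000 nM and 100000 nM, an expected 1.4-fold lower number from compound 2 to compound 3 (0.15 log units; within the scatter).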

Compound 3, half-maximal inhibitory concentration: 7300 nM
Compound 3: middle estimate off by 6.8-fold (0.84 log units), on the high side; the measured number lies below the stated range.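

Putting 3-cyanophenyl in place of iodo on this aromatic carbon gives a 9.7-fold lower number from compound 2 to compound 3 (0.99 log units; beyond the scatter) in this assay, so this position, untouched by the step on the amide nitrogen, clearly moves the read-out. This is the only step here read between two numbers, and the other has a limit at one end: the limit of > 100000 nM in this assay, at which 1 of the 3 values shown sits.

A single change cannot separate the added ring from the nitrile it carries. The compounds shown leave open whether a plain phenyl, or a phenyl bearing a carboxylic acid or an amine in place of the nitrile, would give a similar number.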